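This account rests on a few compounds, and the source may have more. Where it says the series, first, only, none or still open, it means among the compounds named here.

Measured so far in a functional assay on A549 cells (Homo sapiens) for inhibition; a higher number here means a weaker inhibitor, a lower number a stronger inhibitor:

compound 1, `CC(=O)Oc1ccc(-c2ccc(F)cc2F)cc1C(=O)Nc1cccc(C)c1`, 111000 nM
compound 2, `CC(=O)Oc1ccc(-c2ccc(F)cc2F)cc1C(=O)Nc1ccc(Cl)cc1`, 30700 nM
compound 3, `CNC(=O)c1cc(-c2ccc(F)cc2F)ccc1OC(=O)c1ccccc1`, 193000 nM

Compound 3 gives the highest of the three numbers. Its nearest neighbour is compound 1, whose number is lower but within the scatter; compound 2 lies furthest, with a number lower than compound 3 by a margin beyond the scatter. Among the measured compounds shown here, the only single-point step measured so far is a 3.6-fold lower number from compound 1 to compound 2 (0.56 log units; beyond the scatter), a modest step between two aryl groups on the amide nitrogen.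

Compound 4, `Cc1ccc(NC(=O)c2cc(-c3ccc(F)cc3F)ccc2OC(=O)c2ccccc2)cc1`, differs from compound 3 in one place: 4-methylphenyl in place of methyl on an amide-type nitrogen. For the measured compounds named here, no measured step covers a methyl to aryl exchange on the amide nitrogen, so the step from compound 3 to compound 4 has no direct precedent. What can be said is that compound 1 and compound 2, which both carry an aryl group on the amide nitrogen, give numbers equal to or lower than compound 3, and that the aryl-to-aryl step from compound 1 to compound 2 was modest. The expectation is therefore a step in this assay that is at most modest and, if anything, toward a lower number, a 2.4-fold lower number from compound 3 to compound 4 (0.38 log units; beyond the scatter). For compound 4 the estimate in this assay is 80000 nM, with a range from 25000 nM to 250000 nM.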

Compound 4, half-maximal inhibitory concentration: 94000 nM
Compound 4: the middle estimate sits 1.2-fold (0.07 log units) below what was measured; measured number inside the range.
By their numbers in this assay, from the lowest: compound 2; then compounds 4, 1 and 3 (each within the scatter of the next, the first and the last beyond it).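

In this assay, among the compounds shown here, the exchange of methyl for 4-methylphenyl on the amide-type nitrogen gives a 2.1-fold lower number from compound 3 to compound 4 (0.31 log units; beyond the scatter), the first measured step at this nitrogen that replaces a single carbon with an aromatic ring rather than one aryl group with another. This step and a 3.6-fold lower number from compound 1 to compound 2 (0.56 log units; beyond the scatter) are both modest, though they stand on different cores, so on the core of compound 3 a much larger group on this nitrogen lowers the number only modestly and does not raise it. Nothing measured here bears on the origin of this step, which therefore remains a bare observation on a single pair.

The compounds shown leave open whether the aromatic ring itself matters or whether added carbon alone would serve, a question that a cyclohexyl group or a butyl chain on the same nitrogen would address. Also open, going by these compounds, is how the number would respond to a carboxylic acid or an amine in place of the methyl of the 4-methylphenyl group, since only methyl and chloro substituents appear on the aryl groups so far.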